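Swapping a difluorophenyl for a bromodimethoxyphenyl on the hydrazone

The compounds below may be only part of what the source reports. "The series", "measured", "known", "first", "only" and "open" are said of these compounds alone.

Measured so far:
- compound 1 `Fc1ccc(/C=N/Nc2nc(-c3cc(C(F)(F)F)cc(C(F)(F)F)c3)cs2)cc1F` gives 29700 nM
- compound 2 `COc1ccccc1-c1csc(N/N=C/c2cc(Br)c(OC)c(OC)c2)n1` gives > 100000 nM
- compound 3 `Fc1ccc(/C=N/Nc2nc(-c3ccc(Br)cc3)cs2)cc1F` gives > 100000 nM

All three were tested in a functional assay on U-87MG ATCC cells for inhibition, with U-87 MG (Homo sapiens) as the target, read by MTT assay, with a stated time of 48 h; on this read-out lower numbers stand for stronger inhibition and higher numbers for weaker inhibition. For the measured compounds named here, compound 1 is the only compound of the three that returned a number. For compound 2 the result is a limit of the assay rather than a number. For compound 3 the result is likewise a limit of the assay and not a number. So compound 1 stands alone as the one measurable value, with the other two sitting at the limit of > 100000 nM in this assay, at which 2 of the 3 values shown sit.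

Compound 4 `COc1cc(/C=N/Nc2nc(-c3cc(C(F)(F)F)cc(C(F)(F)F)c3)cs2)cc(Br)c1OC` has not yet been measured. It differs from compound 1 in one place: 3-bromo-4,5-dimethoxyphenyl in place of 3,4-difluorophenyl on a carbon with a double bond to nitrogen. The group that enters is the same one that appears in compound 2, while the rest of compound 4 matches compound 1.

Going by the values given here, no step between two measured compounds is available to guide the expectation, so the estimate leans on the values themselves. The step from compound 1 to compound 4 is expected to be a 2.0-fold higher number from compound 1 to compound 4 (0.31 log units; beyond the scatter), towards weaker inhibition, with a real chance that only a limit is returned. Compound 4 is therefore expected to give about 60000 nM, within a range from 20000 nM to 150000 nM.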

Compound 4, half-maximal inhibitory concentration: > 100000 nM
Compound 4: a limit, no number; the forecaster's own chance of this, stated with the estimate: 45%; middle value at least 1.6-fold (0.22 log units) away from the limit.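

In this assay, compound 4 gives > 100000 nM, which is a limit of the assay and not a number. For the compounds shown here, this is the first comparison here between two compounds that differ in one place, and it shows that the group on the carbon with a double bond to nitrogen matters: putting 3-bromo-4,5-dimethoxyphenyl in place of 3,4-difluorophenyl gives an at least 3.3-fold higher number from compound 1 to compound 4 (0.52 log units; beyond the scatter), a shift towards weaker inhibition that lies beyond the scatter. The true size of the step cannot be read, because compound 4 reaches the ceiling of the measurement and so gives only a minimum for the change: the limit of > 100000 nM in this assay, at which 3 of the 4 values shown sit.

The entering group brings a bromine and two methoxy groups together, so the compounds shown leave open whether one of these parts or their combination accounts for the weaker inhibition. They also leave open how inhibition would respond to a different kind of group at this position, such as an amine or a carboxylic acid on the phenyl ring.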